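A few compounds are considered here, and "the series" means these few. Any claim that something is new, unique, unknown or untested is made for them only; others in the source may bear on it.

Compound 1 `Oc1ccc(-c2cc(-c3cccs3)cc(-c3cccc(O)c3)n2)cc1` gives 1770 nM in a functional assay on HCT-15 cells (Homo sapiens) for cytotoxicity, read by CCK-8 assay; on this read-out higher numbers stand for weaker inhibition and lower numbers for stronger inhibition. Compound 3 `Oc1cccc(-c2cc(-c3ccco3)cc(-c3cccc(O)c3)n2)c1` gives 1890 nM in this assay; the difference between the two cores is not broken down here, and the two values lie within the scatter of one another. Compound 2 `Oc1ccc(-c2cc(-c3cccs3)cc(-c3ccc(O)cc3)n2)cc1` is reported only as a limit, > 50000 nM, in this assay. The change 4-hydroxyphenyl in place of 3-hydroxyphenyl on an aromatic carbon produced an at least 28-fold higher number from compound 1 to compound 2 (1.45 log units; beyond the scatter), with compound 2 sitting at the limit of > 50000 nM in this assay, at which 1 of the 3 values shown sits. Compound 4 `Oc1ccc(-c2cc(-c3ccco3)cc(-c3cccc(O)c3)n2)cc1` carries the same kind of change, (4-hydroxyphenyl in place of 3-hydroxyphenyl on an aromatic carbon), though here the place is meta to a 3-hydroxyphenyl group and a furan-2-yl group rather than to a 4-hydroxyphenyl group and a thiophen-2-yl group. Compound 1 likewise keeps one 3-hydroxyphenyl group and gives 1770 nM. On that footing compound 4 is expected to show a far smaller step, a 1.3-fold higher number from compound 3 to compound 4 (0.12 log units; within the scatter). Compound 4 is estimated at 2500 nM, between 1000 nM and 8000 nM.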

Compound 4, half-maximal inhibitory concentration: 840 nM
Compound 4: middle estimate off by 3.0-fold (0.47 log units), on the high side; the whole stated range lies above it.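

In this assay, 4-hydroxyphenyl in place of 3-hydroxyphenyl gives a 2.3-fold lower number from compound 3 to compound 4 (0.35 log units; beyond the scatter), and furan-2-yl in place of thiophen-2-yl gives a 2.1-fold lower number from compound 1 to compound 4 (0.32 log units; beyond the scatter). The hydroxyphenyl change therefore does not carry from one core to the other with the same size or direction: the same change on two cores in this assay, an at least 28-fold higher number (1.45 log units; beyond the scatter) from compound 1 to compound 2 and a 2.3-fold lower number (0.35 log units; beyond the scatter) from compound 3 to compound 4, at least 63-fold (1.80 log units) apart, beyond the scatter of two such steps. This shows that the outcome of the change depends on the core, but not which part of it decides the outcome, as the two cores differ both in the thiophen-2-yl or furan-2-yl group and in the remaining hydroxyphenyl group.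

The compounds shown leave open how the read-out responds when a methoxy group or an amine takes the place of the hydroxyl on these phenyl groups.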